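The source may hold more compounds than are shown below. What is called first, only, known or untested is meant among the compounds shown, and "the series" means these compounds.

Series notes. In an assay for inhibition of serine/threonine-protein kinase PLK2 (Homo sapiens), read by FRET and Z'-LYTE, with a stated time of 1 h (a higher number here means a weaker inhibitor, a lower number a stronger inhibitor), compound 1 `CCC1C(=O)N(C)c2cnc(-n3ccc4cc(C(=O)NC(C)C)ccc43)nc2N1c1ccn(C)n1` gives 125 nM, the second highest of the three numbers in hand. Compound 2 `CC[C@@H]1C(=O)N(C)c2cnc(-n3ccc4ccccc43)nc2N1C1CCCC1` gives 355 nM in this assay, the nearest number and higher than compound 1 by a margin beyond the scatter. Compound 3 `CCCNS(=O)(=O)c1ccc(Nc2ncc3c(n2)N(C2CCCC2)[C@H](CC)C(=O)N3C)cc1` gives 17.8 nM in this assay, the furthest number and the lowest of the three. Compound 4 `CCC1C(=O)N(C)c2cnc(-n3ccc4cc(F)ccc43)nc2N1c1ccn(C)n1` has not yet been run. It differs from compound 1 in one place: fluoro in place of isopropylcarbamoyl on an aromatic carbon. Within the data shown here, no step of this exact kind has been measured, so the expectation rests on the spread from compound 3 through compound 1 to compound 2. The change from compound 1 to compound 4 is expected to move the number upward by a modest amount, a 2.0-fold higher number from compound 1 to compound 4 (0.30 log units; within the scatter), close to the edge of the scatter. Compound 4 is accordingly estimated at 250 nM, with a range from 90 nM to 700 nM.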

Compound 4, half-maximal inhibitory concentration: 1500 nM
Compound 4: middle estimate off by 6.0-fold (0.78 log units), on the low side; the measured number lies above the stated range.
By their numbers in this assay, from the lowest: compound 3; then compound 1; then compound 2; then compound 4.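

In this assay, among these compounds, the isopropylcarbamoyl group on this aromatic carbon counts for much more than the spread of the earlier compounds suggested: fluoro in its place gives a 12-fold higher number from compound 1 to compound 4 (1.08 log units; beyond the scatter) and this is a large step. The change removes a hydrogen-bond donor and acceptor and also shrinks the substituent, so this single step cannot separate those differences. Nothing in hand explains the step. Still open, from the compounds shown here alone, is how much of the group is needed, and a primary carboxamide, a carboxylic acid or a longer amide chain on this carbon would address that.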